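Swapping Iodo for Chloro on a Shared Core

The source may report more compounds than this note shows. Statements on the series, on what has been measured and on what is new or still open speak of the compounds shown alone.

Among the compounds with values here, compound 2 `O=C(O)/C(S)=C/c1c[nH]c2ccc(I)cc12` gives 90 nM in an assay on isolated protein for inhibition of Calpain-1 catalytic subunit (Sus scrofa) (a lower number here means a stronger inhibitor, a higher number a weaker inhibitor), the lowest of the three numbers measured so far. Compound 3 `O=C(O)/C(S)=C/c1c[nH]c2c(I)cccc12`, which carries its iodo elsewhere on the same core, gives 220 nM. Compound 1 `O=C(O)/C(S)=C/c1c[nH]c2ccc(F)cc12` has fluoro where compound 2 has iodo; in this assay compound 1 gives 930 nM. Within the data shown here, the only single-point step measured, a 10-fold lower number from compound 1 to compound 2 (1.01 log units; beyond the scatter), shows how much the choice of halogen here matters. Compound 4 `O=C(O)/C(S)=C/c1c[nH]c2ccc(Cl)cc12` differs from compound 2 by chloro in place of iodo on an aromatic carbon. Chloro sits between fluoro and iodo in the halogen series, so a number between those of compound 1 and compound 2 is expected, a step of a 3.3-fold higher number from compound 2 to compound 4 (0.52 log units; beyond the scatter) toward weaker inhibition. Compound 4 is therefore estimated at 300 nM, with a range from 120 nM to 800 nM.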

Compound 4, half-maximal inhibitory concentration: 50 nM
Beside the measured number, compound 4's estimate is 6.0-fold (0.78 log units) above it; the whole stated range lies above it.
By their numbers in this assay, from the lowest: compounds 4 and 2 (each within the scatter of the next); then compound 3; then compound 1.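

At this position, chloro and iodo cannot be told apart, with a 1.8-fold lower number from compound 2 to compound 4 (0.26 log units; within the scatter). Fluoro is the halogen that stands apart, with a 19-fold lower number from compound 1 to compound 4 (1.27 log units; beyond the scatter), so among compounds 1, 4 and 2 the numbers do not move steadily along the halogen series. Nothing measured here explains why fluoro differs from the other two.

Still open, on these data alone, is how bromo, or a group other than a halogen such as methyl or methoxy, would behave at this position. As far as these compounds go, compound 3 alone carries a halogen elsewhere on the core, so whether chloro would match iodo there also remains open.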